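A few compounds are considered here, and "the series" means these few. Any claim that something is new, unique, unknown or untested is made for them only; others in the source may bear on it.

Notes on the shared core of compound 1 `CCCCSc1nc(N)nc2c1ncn2/C=C1/CC1(CO)CO`. In an ADME assay on HFF cells (Homo sapiens) for cytotoxicity, with a stated time of 8 days (on this read-out higher numbers stand for lower toxicity in this test and lower numbers for higher toxicity in this test), compound 1 gives only a limit, > 300000 nM. Compound 2 `Nc1nc(NC2CC2)c2ncn(/C=C3/CC3(CO)CO)c2n1` likewise reaches only a limit in this assay, > 300000 nM. Compound 3 `Nc1nc(NCc2ccccc2)c2ncn(/C=C3/CC3(CO)CO)c2n1` stands in this assay at a limit as well, > 300000 nM. Compound 3 therefore sits at the limit of > 300000 nM in this assay, at which 3 of the 3 values shown sit, and no order among the three can be read. Compound 4 `CCCCCOc1nc(N)nc2c1ncn2/C=C1/CC1(CO)CO` differs from compound 3 in one place: pentyloxy in place of benzylamino on an aromatic carbon. The measured steps that touch this position are a step that the two limits leave unreadable from compound 1 to compound 3 and a step that the two limits leave unreadable from compound 2 to compound 3, and neither has a readable size. The step of a number no higher from compound 3 to compound 4 (the limit leaves the size open) is accordingly expected to show nothing beyond the scatter. Compound 4 is expected again at the limit, estimated at 300000 nM with a range from 150000 nM to 600000 nM.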

Compound 4, half-maximal cytotoxic concentration: 259000 nM
The estimate for compound 4 lay 1.2-fold (0.06 log units) above the measured number, and the stated range covers the measured number.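

In this assay, pentyloxy on this aromatic carbon gives compound 4, the only compound shown with a number and not a limit. The steps are an at least 1.1-fold lower number from compound 3 to compound 4 (0.06 log units; that floor lies within the scatter), an at least 1.1-fold lower number from compound 2 to compound 4 (0.06 log units; that floor lies within the scatter) and an at least 1.1-fold lower number from compound 1 to compound 4 (0.06 log units; that floor lies within the scatter), so replacing benzylamino, cyclopropylamino or butylsulfanyl with pentyloxy shows no shift beyond the scatter. The other compounds remain at a limit: the limit of > 300000 nM in this assay, at which 3 of the 4 values shown sit.

Going by these compounds, how far compound 1, compound 2 and compound 3 lie beyond that limit remains open. Also open, on these data alone, is whether a longer alkoxy chain or a carboxylic acid at this carbon would lower the number beyond the scatter.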